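Adding an aminosugar to a macrolide core

A few compounds are considered here, and "the series" means these few. Any claim that something is new, unique, unknown or untested is made for them only; others in the source may bear on it.

In a physicochemical assay for lipophilicity, read by HPLC, measured as chromatographic lipophilicity, at pH 7.4 (a higher number here means a more lipophilic compound, a lower number a more polar compound), compound 1 `CCCCCCCC(=O)NCCCN1C[C@H](C)C[C@@](C)(O)[C@H](O)[C@@H](C)[C@H](O)[C@@H](C)C(=O)O[C@H](CC)[C@@](C)(O)[C@H](O)[C@H]1C` gives 3.49, the highest of the three values. Compound 3 `CC[C@H]1OC(=O)[C@H](C)[C@@H](O[C@H]2C[C@@](C)(OC)[C@@H](O)[C@H](C)O2)[C@H](C)[C@@H](O[C@@H]2O[C@H](C)C[C@H](N(C)C)[C@H]2OCCCNC(=O)c2c(C)nn(C)c2Cl)[C@](C)(O)C[C@@H](C)CN(C)[C@H](C)[C@@H](O)[C@]1(C)O` gives 3.08, and compound 2 `CC[C@H]1OC(=O)[C@H](C)[C@@H](O)[C@H](C)[C@@H](O)[C@](C)(O)C[C@@H](C)CN(C)[C@H](C)[C@@H](O)[C@]1(C)O` gives 1.29; the step of a number 2.20 log units lower from compound 1 to compound 2 (beyond the scatter) is large. Compound 4 `CCCCCCCC(=O)NCCCN1C[C@H](C)C[C@@](C)(O)[C@H](O[C@@H]2O[C@H](C)C[C@H](N(C)C)[C@H]2O)[C@@H](C)[C@H](O)[C@@H](C)C(=O)O[C@H](CC)[C@@](C)(O)[C@H](O)[C@H]1C` differs from compound 1 by 4-(dimethylamino)-3-hydroxy-6-methyloxan-2-yl in place of hydrogen on an oxygen on a saturated carbon. Going by the values given here, no measured step shows this change alone; compound 3 carries such a group but differs from compound 2 in several places, so their two values only show that a glycosylated core can sit well above the bare core. A modest downward step, or none beyond the scatter, is therefore expected, a number 0.39 log units lower from compound 1 to compound 4 (beyond the scatter). Compound 4 is estimated at 3.1, between 2.5 and 3.7.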

Compound 4, distribution coefficient: 3.08
Compound 4: the middle estimate sits 0.02 log units above what was measured, and the stated range covers the measured number.
By their numbers in this assay, from the lowest: compound 2; then compounds 3 and 4 (each within the scatter of the next); then compound 1.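

Placing 4-(dimethylamino)-3-hydroxy-6-methyloxan-2-yl on an oxygen on a saturated carbon of the core of compound 1 gives, in this assay, a number 0.41 log units lower from compound 1 to compound 4 (beyond the scatter). Going by these compounds alone, this is the first reading of that change alone at this position, and the step is modest, so the compound carrying the group still stands well above compound 2 at 1.29. Nothing available accounts for the size of this step.

As far as these compounds go, it remains open whether a carboxylic acid in place of the dimethylamino group would shift the number, and whether a longer chain on the amine nitrogen in a ring would alter the size of this step.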